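This account rests on a few compounds, and the source may have more. Where it says the series, first, only, none or still open, it means among the compounds named here.

Working notes on the series. Compound 1 `CCCC[C@H](CO)Nc1nc(N)nc2cccnc12` gives 790 nM in an assay on tissue (PBMC cells) for agonist activity at Toll-like receptor 8 (Homo sapiens), with a stated time of 24 h; on this read-out higher numbers stand for an effect only at larger amounts of compound and lower numbers for an effect already at smaller amounts. Compound 2 `CCCC[C@H](CN)Nc1nc(N)nc2cccnc12` gives 25000 nM in this assay. The step of a 32-fold higher number from compound 1 to compound 2 (1.50 log units; beyond the scatter) is the only one on record. Going by the values given here, compound 2 therefore stands at the highest of the two numbers, with compound 1 as its only neighbour.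

Compound 3 `CCCC[C@@H](Nc1nc(N)nc2cccnc12)C(=O)NC` is the next structure to be measured. It differs from compound 2 by methylcarbamoyl in place of aminomethyl on a saturated chain carbon bound to a nitrogen on an aromatic ring and a saturated chain carbon. Among the compounds with values here, no measured step covers a carbamoyl group here; the only related information is the step from compound 1 to compound 2, which shows that the aminomethyl form of the chain sits at the high end of the numbers. Because a 32-fold higher number from compound 1 to compound 2 (1.50 log units; beyond the scatter) was large, removing the aminomethyl group is expected to move compound 3 back toward lower numbers, by a 6.3-fold lower number from compound 2 to compound 3 (0.80 log units; beyond the scatter). Compound 3 is therefore estimated at 4000 nM in this assay, within 800 nM to 20000 nM.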

Compound 3, half-maximal effective concentration: > 50000 nM
Compound 3: only a limit was reported (the forecaster's own chance of this, stated with the estimate: 5%); middle value at least 12-fold (1.09 log units) from the limit.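

In this assay compound 3 is reported only as a limit, not as a number: the limit of > 50000 nM in this assay, at which 1 of the 3 values shown sits. Set against the hydroxymethyl form, methylcarbamoyl gives an at least 63-fold higher number from compound 1 to compound 3 (1.80 log units; beyond the scatter), so on a saturated chain carbon bound to a nitrogen on an aromatic ring and a saturated chain carbon, a second replacement moves the number the same way as aminomethyl did, and among these three compounds none goes against that. Against the aminomethyl form the result is an at least 2.0-fold higher number from compound 2 to compound 3 (0.30 log units; that floor lies within the scatter), so the limit does not firmly place compound 3 apart from compound 2.

Going by these compounds, how far compound 3 lies past its limit remains open, and so does the size of the gap to compound 2. On these data alone, whether a primary carboxamide, a carboxylic acid, a methoxymethyl or a hydroxyethyl group would keep the number of compound 1 is also open.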